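Extending the Amino Group of Compound 1 with an Aminobutyl Chain

This account rests on a few compounds, and the source may have more. Where it says the series, first, only, none or still open, it means among the compounds named here.

Compound 1 `COc1ccc(-c2cc(-c3ccc(S(C)(=O)=O)cc3)cnc2N)cn1`: 6.2 mL.min-1.g-1
Compound 2 `CS(=O)(=O)c1ccc(-c2cnc(N)c(-c3ccc(C(F)(F)F)cc3)n2)cc1`: 11 mL.min-1.g-1
Compound 3 `COc1ccc(-c2nc(-c3ccc(S(C)(=O)=O)cc3)cnc2N)cn1`: 11 mL.min-1.g-1

These three compounds share a core and were measured in an ADME assay (liver) for metabolic stability, with Liver microsome (Homo sapiens) as the target, read by LC-MS, using microsomes; a higher number here means faster removal of the compound, a lower number slower removal. Compound 1 gives 6.2 mL.min-1.g-1, and the gaps to compound 2 and to compound 3 both lie within the usual scatter, so all three are read as equivalent. Compound 4 `COc1ccc(-c2cc(-c3ccc(S(C)(=O)=O)cc3)cnc2NCCCCN)cn1` has not been measured. It differs from compound 1 in one place: 4-aminobutyl in place of hydrogen on a nitrogen on an aromatic ring. Among the measured compounds shown here, no measured pair shows this kind of change, so there is no step to lean on. The chain is expected to leave the number roughly where compound 1 sits, with the step of a 1.0-fold higher number from compound 1 to compound 4 (0.02 log units; within the scatter) expected to stay within the scatter. Compound 4 is expected to give 6.5 mL.min-1.g-1, between 2.5 mL.min-1.g-1 and 16 mL.min-1.g-1.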

Compound 4, intrinsic clearance in microsomes in the Liver microsome assay: < 7 mL.min-1.g-1
Compound 4: a limit, no number (the forecaster's own chance of this, stated with the estimate: 5%); the middle value is on the limit's open side.
By their numbers in the Liver microsome assay, from the lowest: compounds 1, 2 and 3 (each within the scatter of the next).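

Among the compounds shown here, in the Liver microsome assay compound 4 gives < 7 mL.min-1.g-1, a limit and not a number, and no step from compound 1 to compound 4 can be read. In a physicochemical assay for solubility, measured as kinetic solubility, at pH 6.5 (a lower number here means a less soluble compound, a higher number a more soluble compound), compound 1 gives 121 ug/mL and compound 4 gives 25 ug/mL. The compounds shown leave open how far the 4-aminobutyl chain moves the number in the Liver microsome assay.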